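The source may report more compounds than this note shows. Statements on the series, on what has been measured and on what is new or still open speak of the compounds shown alone.

In a toxicity assay on microsomes from liver (Homo sapiens) for metabolic stability, read by LC-MS, using NADPH, tested at 1 uM (a lower number here means slower removal, a higher number faster removal of the compound), compound 2 `Cc1ncc(-c2nc(C(F)(F)F)sc2N2CCN(C(=O)Cn3nc(C)nc3C)[C@H](C)C2)cn1` gives < 10 mL.min-1.g-1, which is a limit of the assay and not a number. Compound 2 therefore stands at the limit of < 10 mL.min-1.g-1 in this assay, at which 1 of the 2 values shown sits. Compound 1 `Cc1nc(C)n(CC(=O)N2CCN(c3sc(C(F)(F)F)nc3-c3cnc(OC4CCC4)nc3)C[C@H]2C)n1` carries cyclobutyloxy where compound 2 has methyl. Compound 1 gives a measured 51 mL.min-1.g-1. The next structure, compound 3 `Cc1nc(C)n(CC(=O)N2CCN(c3sc(C(F)(F)F)nc3-c3cnc(C(C)(C)C)nc3)C[C@H]2C)n1`, has tert-butyl in place of methyl on an aromatic carbon, at the site between two ring nitrogen atoms. For the measured compounds named here, only one measured step bears on this site: methyl in place of cyclobutyloxy, which gave an at least 5.1-fold lower number from compound 1 to compound 2 (0.70 log units; beyond the scatter). From the compounds shown here alone, it lies beyond the scatter, but one end of it is a limit, so its true size remains open. It also involves a different group from tert-butyl, so it offers only a rough guide. Going by compound 1 at 51 mL.min-1.g-1, replacing this methyl is expected to raise the number in this assay, probably by somewhat less than the full measured step. The expected change is an at least 2.5-fold higher number from compound 2 to compound 3 (0.39 log units; beyond the scatter). For compound 3 the estimated value is 25 mL.min-1.g-1, within an expected range of 10 mL.min-1.g-1 to 60 mL.min-1.g-1.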

Compound 3, intrinsic clearance in microsomes: 449 mL.min-1.g-1
For compound 3 the middle estimate is 18-fold (1.25 log units) below the measured one, outside the stated range (above it).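

At this site, between two ring nitrogen atoms, the number in this assay turns out to be far more sensitive to the group than the earlier pair could show: swapping methyl for tert-butyl brings an at least 44-fold higher number from compound 2 to compound 3 (1.65 log units; beyond the scatter). The high number also does not depend on the oxygen-linked cyclobutyloxy, since tert-butyl, which enters with no hydrogen-bond acceptor, goes well past it, with an 8.8-fold higher number from compound 1 to compound 3 (0.94 log units; beyond the scatter); of the three groups at this site, tert-butyl gives the highest number and methyl the lowest, each step lying beyond the scatter. For compound 2 the value is a limit of the assay and not a number, so the larger step has an open size: the limit of < 10 mL.min-1.g-1 in this assay, at which 1 of the 3 values shown sits.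

What the compounds shown leave open is how the number moves through the groups of intermediate bulk, such as ethyl, isopropyl or cyclopropyl, and so whether it climbs gradually from methyl or jumps only with tert-butyl. They also leave open whether a nitrogen-linked group such as dimethylamino, or a small methoxy group, would stay near methyl or rise towards cyclobutyloxy.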